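A few compounds are considered here, and "the series" means these few. Any claim that something is new, unique, unknown or untested is made for them only; others in the source may bear on it.

Compound 1 `OB1OCc2ccc(-n3cccc3)cc21` stands only at a limit on the numbers shown. In an ADME assay on L929 cells (Mus musculus) for cytotoxicity, read by resazurin assay, with a stated time of 72 h (on this read-out lower numbers stand for stronger inhibition and higher numbers for weaker inhibition), compound 1 gives > 10 ug/mL, which is a limit of the assay rather than a number. Compound 2 `NCCCC(=O)c1ccn(-c2ccc3c(c2)B(O)OC3)c1` is its nearest measured neighbour. In this assay compound 2 gives > 10 ug/mL, likewise a limit. The step that the two limits leave unreadable from compound 1 to compound 2 therefore cannot be read, owing to the limit of > 10 ug/mL in this assay, at which 2 of the 2 values shown sit. Compound 3 `CC(=O)c1cccn1-c1ccc2c(c1)B(O)OC2` carries acetyl in place of hydrogen on an aromatic carbon. Going by the values given here, no measured step offers a readable size for this change, so in this assay compound 3 is expected to show no step beyond the scatter, a step that the limit leaves unreadable from compound 1 to compound 3. Compound 3 is estimated at 20 ug/mL, between 8 ug/mL and 60 ug/mL.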

Compound 3, half-maximal inhibitory concentration: > 10 ug/mL
Compound 3: only a limit was reported; the forecaster's own chance of this, stated with the estimate: 80%; the middle value does not contradict the limit.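

Compound 3 also stands at a limit, so no new step can be read between compound 1 and compound 3: the limit of > 10 ug/mL in this assay, at which 3 of the 3 values shown sit. As far as these compounds go, whether acetyl or (3-aminopropyl)carbonyl in place of hydrogen shifts the value in this assay at all stays open.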